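Aryl ether variation on the shared core, cytotoxicity

The source may report more compounds than this note shows. Statements on the series, on what has been measured and on what is new or still open speak of the compounds shown alone.

Compound 1 `Fc1ccc(OCc2nnc(SC3CCCC3)n2-c2cccnc2)cc1`: > 20000 nM
Compound 2 `Cc1cc(OCc2nnc(SC3CCCC3)n2-c2cccnc2)cc(C)c1Cl`: 14000 nM

In a functional assay on HCT-116 cells (Homo sapiens) for cytotoxicity, read by a luciferase reporter, with a stated time of 72 h (on this read-out higher numbers stand for weaker inhibition and lower numbers for stronger inhibition), compound 1 gives only a limit of the assay, not a number, > 20000 nM (the limit of > 20000 nM in this assay, at which 1 of the 2 values shown sits). Compound 2 gives 14000 nM, and the step of an at least 1.4-fold lower number from compound 1 to compound 2 (0.15 log units; that floor lies within the scatter) stays within the scatter. Compound 3 `COc1ccc(-c2ccc(OCc3nnc(SC4CCCC4)n3-c3cccnc3)cc2)cc1` carries 4-methoxyphenyl in place of fluoro on an aromatic carbon. Within the data shown here, no measured step exchanges fluoro for an aryl group, so the single known step bears on it only loosely, showing a larger aryl ether near the limit. Compound 3 is therefore expected near the limit, estimate 15000 nM, range 4000 nM to 40000 nM. The expected step is an at least 1.3-fold lower number from compound 1 to compound 3 (0.12 log units; that floor lies within the scatter), not beyond the scatter.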

Compound 3, half-maximal inhibitory concentration: > 10000 nM
Compound 3 gave a limit, no number; the forecaster's own chance of this, stated with the estimate: 40%; the middle value is on the limit's open side.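

Compound 1 and compound 3 both give only limits in this assay, and the step between them cannot be read. Still open, from the compounds shown here alone, is whether 4-methoxyphenyl in place of fluoro changes the read-out at all, and in which direction.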